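This account rests on a few compounds, and the source may have more. Where it says the series, first, only, none or still open, it means among the compounds named here.

Measured so far:
Compound 1 `CN(CCC#N)C[C@H]1CN(c2ccc(-n3cc(-c4ccccn4)cn3)c(F)c2)C(=O)O1` in an ADME assay on HEK293-A cells (Homo sapiens) for cytotoxicity, read by MTT assay, with a stated time of 48 h (on this read-out higher numbers stand for weaker inhibition and lower numbers for stronger inhibition), gives > 400 ug/mL, a limit of the assay.
Compound 2 `O=C1CCC(=O)N1C[C@H]1CN(c2ccc(-n3cc(-c4ccccn4)cn3)c(F)c2)C(=O)O1` in this assay gives > 400 ug/mL, again a limit.
Compound 3 `O=C1O[C@@H](CSc2cccs2)CN1c1ccc(-n2cc(-c3ccccn3)cn2)c(F)c1` in this assay gives > 400 ug/mL, also a limit.

Compound 1 therefore stands nowhere in particular on the numbers shown: its value is a limit, and the two further values are limits as well, all three sitting at the limit of > 400 ug/mL in this assay, at which 3 of the 3 values shown sit. The three measured steps, a step that the two limits leave unreadable from compound 1 to compound 2, a step that the two limits leave unreadable from compound 1 to compound 3 and a step that the two limits leave unreadable from compound 2 to compound 3, are accordingly unreadable in size and direction; none shows that any change on the saturated chain carbon bound to a saturated ring carbon moves the read-out off the limit.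

Compound 4 `COC(=O)NC[C@H]1CN(c2ccc(-n3cc(-c4ccccn4)cn3)c(F)c2)C(=O)O1` is the next member. Relative to compound 1 the change is (methoxycarbonyl)amino in place of (2-cyanoethyl)(methyl)amino on a saturated chain carbon bound to a saturated ring carbon. Among the measured compounds shown here, no measured step bears on this change in a readable way; the only comparison available is that three different groups at the same place all leave compound 1, compound 2 and compound 3 at the limit. The expected step of a number no higher from compound 1 to compound 4 (the limit leaves the size open) is therefore none beyond the scatter, and compound 4 is expected to report in this assay at 400 ug/mL, between 200 ug/mL and 800 ug/mL, most likely again as a limit.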

Compound 4, half-maximal inhibitory concentration: 306 ug/mL
Beside the measured number, compound 4's estimate is 1.3-fold (0.12 log units) above it; measured number inside the range.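

In this assay compound 4 gives 306 ug/mL, so (methoxycarbonyl)amino is the one group of the four shown on the saturated chain carbon bound to a saturated ring carbon that returns a number rather than a limit. Compound 1, compound 2 and compound 3 each stay at a limit: the limit of > 400 ug/mL in this assay, at which 3 of the 4 values shown sit.

Against these three, the steps are an at least 1.3-fold lower number from compound 1 to compound 4 (0.11 log units; that floor lies within the scatter), an at least 1.3-fold lower number from compound 2 to compound 4 (0.11 log units; that floor lies within the scatter) and an at least 1.3-fold lower number from compound 3 to compound 4 (0.11 log units; that floor lies within the scatter); each floor lies within the scatter, so a reading at this position is now shown, but no change of real size is established for (methoxycarbonyl)amino in place of any of the three groups.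

The steps among compound 1, compound 2 and compound 3 cannot be read, and how far each of these compounds lies from compound 4 stays open. Also open, on these data alone, is whether a primary amine, an acetamide or a carboxylic acid on the same saturated chain carbon would give a number in this assay, and whether that number would lie beyond the scatter from compound 4.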